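The compounds below may be only part of what the source reports. "The series", "measured", "known", "first", "only" and "open" are said of these compounds alone.

Compound 1 `COc1ccc2nc(Cl)c(Cn3cc(CN4c5ccccc5C(C)=CC4(C)C)nn3)cc2c1` in a functional assay on DU-145 cells (Homo sapiens) for cytotoxicity, read by MTT assay, with a stated time of 48 h (a higher number here means a weaker inhibitor, a lower number a stronger inhibitor), gives 34000 nM.
Compound 2 `CC1=CC(C)(C)N(Cc2cn(Cc3cc4ccccc4nc3Cl)nn2)c2ccccc21` in this assay gives 19300 nM.

Going by the values given here, compound 1 stands highest of the two numbers measured so far, but only by a narrow margin: the nearest compound, compound 2, lies a 1.8-fold lower number from compound 1 to compound 2 (0.25 log units; within the scatter), so the two cannot be told apart on these data.

Compound 3 `COc1ccc2nc(Cl)c(Cn3cc(CN4c5ccc(C)cc5C(C)=CC4(C)C)nn3)cc2c1` keeps the whole of compound 1 and changes a single point: methyl in place of hydrogen on an aromatic carbon. Among the compounds with values here, the one measured step, from compound 1 to compound 2, alters a different part of the shared core and stayed within the scatter. Within the data shown here, no measured pair speaks to a methyl entering at this position, so the data give no direction for the change, and the one comparison available shows that a small change to the shared core left the number essentially unchanged.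

The expectation for compound 3 is therefore a number close to that of compound 1, with no step beyond the scatter; the estimated step is a 1.1-fold lower number from compound 1 to compound 3 (0.05 log units; within the scatter). Compound 3 is estimated at 30000 nM, with a range from 10000 nM to 90000 nM.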

Compound 3, half-maximal inhibitory concentration: 19800 nM
Compound 3: middle estimate off by 1.5-fold (0.18 log units), on the high side; the measured number falls inside the stated range.
By their numbers in this assay, from the lowest: compounds 2, 3 and 1 (each within the scatter of the next).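

Methyl in place of hydrogen, on an aromatic carbon of a six-membered aromatic ring of carbon only that is part of a fused or bridged system of two rings, gives a 1.7-fold lower number from compound 1 to compound 3 (0.23 log units; within the scatter) in this assay and so gives the first reading at this position. One added carbon here therefore leaves compound 3 and compound 1 indistinguishable in this read-out. It is also the second one-place change from compound 1 to stay within the scatter, alongside the change at a different place on the shared core, which gave a 1.8-fold lower number from compound 1 to compound 2 (0.25 log units; within the scatter) in this assay, while no measurement shown here bears on what lies behind this result.

As far as these compounds go, a single methyl is only one probe of this aromatic carbon, so it remains open whether a longer chain such as propyl, an amine or a carboxylic acid at the same place would move the number beyond the scatter. From the compounds shown here alone, it is also open whether a methyl on the other aromatic carbons of that ring would behave as this one does.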